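The compounds below may be only part of what the source reports. "The series", "measured", "known", "first", "only" and "open" are said of these compounds alone.

Measured so far in an assay on isolated protein for inhibition of phosphodiesterase 4A (Sus scrofa); a lower number here means a stronger inhibitor, a higher number a weaker inhibitor:
compound 1 `COc1ccc(C(=O)Nc2ccccc2Cl)cc1OC1CCCC1` gives 190 nM
compound 2 `COc1ccc(C(=O)Nc2ccccc2Br)cc1OC1CCCC1` gives 130 nM
compound 3 `COc1ccc(C(=O)Nc2ccccn2)cc1OC1CCCC1` gives 1000 nM

Compound 3 has the highest number of the three; the steps of a 5.3-fold higher number from compound 1 to compound 3 (0.72 log units; beyond the scatter) and a 7.7-fold higher number from compound 2 to compound 3 (0.89 log units; beyond the scatter) both run upward beyond the scatter, while a 1.5-fold lower number from compound 1 to compound 2 (0.16 log units; within the scatter) stays within it. Compound 4 `COc1ccc(C(=O)Nc2ccncc2)cc1OC1CCCC1` differs from compound 3 in one place: pyridin-4-yl in place of pyridin-2-yl on an amide-type nitrogen. For the measured compounds named here, no measured step compares the two pyridinyl groups with each other; the steps to compound 3 concern exchanging a halogenated phenyl for pyridin-2-yl and do not show what moving the ring nitrogen does. The estimate for compound 4 therefore stays near compound 3 with a wide range, as a step of a 2.0-fold lower number from compound 3 to compound 4 (0.30 log units; within the scatter). Compound 4 is expected to give about 500 nM, between 80 nM and 2500 nM.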

Compound 4, half-maximal inhibitory concentration: 800 nM
The estimate for compound 4 lay 1.6-fold (0.20 log units) below the measured number, within the range that was stated.
By their numbers in this assay, from the lowest: compounds 2 and 1 (each within the scatter of the next); then compounds 4 and 3 (each within the scatter of the next).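

In this assay, swapping pyridin-2-yl for pyridin-4-yl on the amide-type nitrogen gives a step within the scatter (a 1.3-fold lower number from compound 3 to compound 4 (0.10 log units; within the scatter)), so the place of the ring nitrogen does not separate these two compounds. The gap to the halogenated phenyl compounds also holds for this second pyridinyl group (a 6.2-fold higher number from compound 2 to compound 4 (0.79 log units; beyond the scatter); a 4.2-fold higher number from compound 1 to compound 4 (0.62 log units; beyond the scatter)), so it is not peculiar to pyridin-2-yl.

No supporting data explain this gap. Going by these compounds, it remains open whether an unsubstituted phenyl or pyridin-3-yl at this place would group with the halogenated phenyl compounds or the pyridinyl ones.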